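Replacing an aryl group by isopropyl on the shared core

The compounds below may be only part of what the source reports. "The series", "measured", "known", "first", "only" and "open" are said of these compounds alone.

Compound 1 `COc1ccc(N/C(CCNC2=CC(=O)c3ccccc3C2=O)=N\S(=O)(=O)c2ccc(C)cc2)cc1`: 12000 nM
Compound 2 `Cc1ccc(S(=O)(=O)/N=C(/CCNC2=CC(=O)c3ccccc3C2=O)Nc2ccccc2[N+](=O)[O-])cc1`: 7590 nM
Compound 3 `Cc1ccc(S(=O)(=O)/N=C(/CCNC2=CC(=O)c3ccccc3C2=O)Nc2cc(F)c(F)c(F)c2)cc1`: 12600 nM

In a functional assay on DU-145 cells (Homo sapiens) for cytotoxicity, read by MTT assay, with a stated time of 48 h (a lower number here means a stronger inhibitor, a higher number a weaker inhibitor), compound 2 gives 7590 nM. This is the lowest of the three numbers, yet its steps to both neighbours, a 1.6-fold lower number from compound 1 to compound 2 (0.20 log units; within the scatter) and a 1.7-fold higher number from compound 2 to compound 3 (0.22 log units; within the scatter), lie within the scatter, so no order among compounds 1, 2 and 3 can be read from them. The third step, a 1.1-fold higher number from compound 1 to compound 3 (0.02 log units; within the scatter), is equally flat. All three measured compounds carry an aromatic group on the same amine nitrogen, and exchanging one such group for another left this assay essentially unchanged.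

Compound 4 `Cc1ccc(S(=O)(=O)/N=C(/CCNC2=CC(=O)c3ccccc3C2=O)NC(C)C)cc1` departs from compound 2 by isopropyl in place of 2-nitrophenyl on an amine nitrogen. For the measured compounds named here, no measured step bears directly on this change, since none of the measured compounds carries a non-aromatic group at that position; the three aryl exchanges only show that the groups tried so far are interchangeable in this assay. The step of a 1.3-fold higher number from compound 2 to compound 4 (0.12 log units; within the scatter) is therefore expected to be small, with a somewhat widened range to allow for the unprecedented change. For compound 4 an estimate of 10000 nM is given, with a range from 4000 nM to 30000 nM.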

Compound 4, half-maximal inhibitory concentration: 28500 nM
Estimate against measurement, compound 4: 2.9-fold (0.45 log units) below, and the stated range covers the measured number.
By their numbers in this assay, from the lowest: compounds 2, 1 and 3 (each within the scatter of the next); then compound 4.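

The amine nitrogen carrying these groups is not indifferent to every substituent: the exchanges among aromatic groups had left this assay flat, but isopropyl moves the number beyond the scatter from each of the three aryl compounds. For the compounds shown here, the largest of these steps is the one from the 2-nitrophenyl compound (a 3.8-fold higher number from compound 2 to compound 4 (0.57 log units; beyond the scatter)), and the steps from the other two aryl compounds are also modest but clear (a 2.4-fold higher number from compound 1 to compound 4 (0.38 log units; beyond the scatter) and a 2.3-fold higher number from compound 3 to compound 4 (0.35 log units; beyond the scatter)). Compound 4 therefore has the highest number of the four, and none of the three aryl compounds goes against this, so within this small set an aromatic ring on this nitrogen goes with a lower number than isopropyl does.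

The compounds shown do not separate the loss of the ring from the change in the group's size or shape, a question that a cyclohexyl group, a benzyl group or a longer alkyl chain at this nitrogen could address. Why isopropyl raises the number also stays unexplained, as no supporting measurement bears on this change.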